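This account rests on a few compounds, and the source may have more. Where it says the series, first, only, none or still open, it means among the compounds named here.

Compound 1 `O=C(O)CCCOc1ccc(-c2cccc(Oc3ccccc3)c2)cc1`: in a functional assay on isolated protein for agonist activity at Free fatty acid receptor 1 (Homo sapiens), read by HTRF and inositol phosphate accumulation, with a stated time of 60 min (a higher number here means that more compound is needed for the effect, a lower number that less compound is needed), compound 1 gives 6800 nM.
Compound 2 `Cc1ccc(Oc2cccc(-c3ccc(OCCCC(=O)O)cc3)c2)cc1`: in this assay compound 2 gives only a limit of the assay, > 9950 nM.

Compound 2 thus stands at the edge of what this assay reports; its value is a limit, not a number (the limit of > 9950 nM in this assay, at which 1 of the 2 values shown sits). Among the compounds with values here, the only measured step, an at least 1.4-fold higher number from compound 1 to compound 2 (0.16 log units; that floor lies within the scatter), is a change that the usual scatter could account for. Compound 3 `O=C(O)CCCOc1ccc(-c2cccc(OCc3ccccc3)c2)cc1` differs from compound 2 by benzyl in place of 4-methylphenyl on an oxygen on an aromatic ring. Within the data shown here, no measured step covers this exchange; the step from compound 1 to compound 2 concerns only the methyl group and gives no guide to a benzyl group in place of 4-methylphenyl. Compound 2 offers only a limit. The expectation therefore leans on compound 1, which in this assay gives 6800 nM. Compound 3 is therefore expected near 8000 nM, between 2500 nM and 25000 nM, and may well return only a limit again. The expected step of an at least 1.2-fold lower number from compound 2 to compound 3 (0.09 log units; that floor lies within the scatter) is accordingly within the scatter.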

Compound 3, half-maximal effective concentration: > 9950 nM
Compound 3: only a limit was reported (the forecaster's own chance of this, stated with the estimate: 40%); at least 1.2-fold (0.09 log units) between middle value and limit.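

In this assay, benzyl on this oxygen gives no readable gain over the phenyl of compound 1: the change is an at least 1.4-fold higher number from compound 1 to compound 3 (0.16 log units; that floor lies within the scatter). Compound 3 ends as a limit of the assay and not as a number, and so the exchange of 4-methylphenyl for benzyl, two groups with the same count of carbon atoms and one aromatic ring each, cannot be read, nor can any other step between two limits. With compound 3, the limit now holds most of the series shown: the limit of > 9950 nM in this assay, at which 2 of the 3 values shown sit.

As far as these compounds go, how far compound 2 and compound 3 lie past that limit remains open, so the two cannot be ordered. Also open, from the compounds shown here alone, is whether a different group on this oxygen, such as a longer chain ending in an amine, would return a value that can be read as a number.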